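A few compounds are considered here, and "the series" means these few. Any claim that something is new, unique, unknown or untested is made for them only; others in the source may bear on it.

Two compounds of this series have been examined in a functional assay on K562 cells (Homo sapiens) for inhibition, read by sulforhodamine B assay, with a stated time of 48 h; a lower number here means a stronger inhibitor of growth, a higher number a weaker inhibitor of growth. Compound 1, with the structure `O=C(Nc1cccc(-n2cc(-c3ccncc3)c(-c3ccc(Cl)c(O)c3)n2)c1)Nc1cccc(C(F)(F)F)c1`, carries a hydroxyl on one aryl ring and a 3-(trifluoromethyl)phenyl group on the urea. In this assay compound 1 reaches only a limit, > 32500 nM. Compound 2, with the structure `COc1cc(-c2nn(-c3cccc(NC(=O)Nc4ccc(Cl)c(Cl)c4)c3)cc2-c2ccncc2)ccc1Cl`, carries a methoxy in place of that hydroxyl and a 3,4-dichlorophenyl group on the urea. In this assay compound 2 likewise reaches only a limit, > 50000 nM; so compound 2 stands among the compounds for which no number, only a limit, is known, as the limit of > 50000 nM in this assay, at which 1 of the 2 values shown sits, and the limit of > 32500 nM in this assay, at which 1 of the 2 values shown sits, both show.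

Compound 3, with the structure `COc1cc(-c2nn(-c3cccc(NC(=O)Nc4cccc(C(F)(F)F)c4)c3)cc2-c2ccncc2)ccc1Cl`, differs from compound 2 in one place: 3-(trifluoromethyl)phenyl in place of 3,4-dichlorophenyl on an amide-type nitrogen. Among the compounds with values here, no measured pair shows what this change does. Both compounds that are known here give only limits, so no shift beyond the usual scatter is expected, and compound 3 is expected to give another limit. The step from compound 2 to compound 3 is therefore estimated as an at least 1.1-fold lower number from compound 2 to compound 3 (0.04 log units; that floor lies within the scatter). For compound 3 the expected result is 45000 nM, with a range from 15000 nM to 120000 nM.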

Compound 3, concentration for total growth inhibition: > 50000 nM
Compound 3 was reported as a limit; the forecaster's own chance of this, stated with the estimate: 80%; at least 1.1-fold (0.04 log units) between middle value and limit.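

Compound 1, compound 2 and compound 3 all give only limits in this assay, so no step can be read from compound 2 to compound 3 or from compound 1 to compound 3. The compounds shown leave open how strongly any of them inhibits growth, and whether either change on its own makes any difference.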